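Swapping the Aryl Group on a Urea Nitrogen

The source may hold more compounds than are shown below. What is called first, only, known or untested is meant among the compounds shown, and "the series" means these compounds.

Three ureas sharing one core have been measured in an assay on microsomes from intestine for inhibition of acyl-CoA:cholesterol acyltransferase (Oryctolagus cuniculus); a lower number here means a stronger inhibitor, a higher number a weaker inhibitor. Compound 1 `COc1ccccc1NC(=O)NCC1(c2ccccc2)CCCCC1` gives 270 nM. Compound 2 `CC(C)c1ccccc1NC(=O)NCC1(c2ccccc2)CCCCC1` gives 390 nM, and compound 3 `O=C(NCC1(c2ccccc2)CCCCC1)Nc1ccccc1C(F)(F)F` gives 200 nM. Among these three numbers compound 1 stands second highest; its nearest neighbour is compound 3 and its furthest is compound 2. The steps between the measured compounds are all small: a 1.4-fold higher number from compound 1 to compound 2 (0.16 log units; within the scatter), a 1.4-fold lower number from compound 1 to compound 3 (0.13 log units; within the scatter) and a 2.0-fold lower number from compound 2 to compound 3 (0.29 log units; within the scatter).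

Compound 4 `Cc1cccc(NC(=O)NCC2(c3ccccc3)CCCCC2)c1` differs from compound 1 by 3-methylphenyl in place of 2-methoxyphenyl on an amide-type nitrogen. Among the compounds with values here, none of the measured steps exchanges the whole aryl group in this way; each of them changes only the substituent on an aromatic carbon, and every one of those steps stayed within the scatter of this assay. On that basis the change from compound 1 to compound 4 is expected to give no step beyond the scatter in this assay, and its direction cannot be told from the three measured compounds. The estimate for compound 4 in this assay is 300 nM, with a range from 120 nM to 750 nM, which corresponds to an expected step of a 1.1-fold higher number from compound 1 to compound 4 (0.05 log units; within the scatter).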

Compound 4, half-maximal inhibitory concentration: 2800 nM
For compound 4 the middle estimate is 9.3-fold (0.97 log units) below the measured one; measured number above the stated range.
By their numbers in this assay, from the lowest: compounds 3, 1 and 2 (each within the scatter of the next); then compound 4.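

In this assay, within the data shown here, exchanging the aryl group on the amide-type nitrogen gives a 10-fold higher number from compound 1 to compound 4 (1.02 log units; beyond the scatter), so this position is far less forgiving than the earlier compounds alone suggested. Among compounds 1, 2 and 3, methoxy, isopropyl and trifluoromethyl on an aromatic carbon all gave numbers within the scatter of the next, while compound 4, with 3-methylphenyl, stands apart from all three at the weak end of the series. The change from 2-methoxyphenyl to 3-methylphenyl therefore matters a great deal here, but no measurement shown explains why the number moves so far.

The single step replaces the methoxy group with methyl and also changes the numbered place of the substituent in the group's name, so the compounds shown cannot say which of these two differences carries the large step. They also leave open how an unsubstituted phenyl group on this nitrogen, or an aryl group carrying a dimethylamino group or a carboxylic acid, would behave in this assay.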